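Sec-butoxy in place of diethylamino on the carbonyl carbon

This account rests on a few compounds, and the source may have more. Where it says the series, first, only, none or still open, it means among the compounds named here.

Within the data shown here, compound 3 `CCN(CC)C(=O)C1=C(C)NC(=O)NC1c1ccsc1` gives 11% in an assay on membranes from CHO cells for displacement of a labelled ligand from adenosine receptor A1 (Homo sapiens), read by scintillation counting, with a stated time of 60 min, tested at 1 uM (a higher number here means more inhibition at the concentration tested (going by the name of the read-out), a lower number less inhibition), numerically the largest of the three numbers measured so far, though it sits within the scatter of both others. Compound 1 `CC(=O)C1=C(C)NC(=O)NC1c1ccsc1` gives 9% and compound 2 `CC1=C(C(N)=O)C(c2ccsc2)NC(=O)N1` gives 2%. All three measured steps vary the same substituent on the carbonyl carbon and none of them leaves the scatter: a number 7 percentage points lower from compound 1 to compound 2 (within the scatter), a number 2 percentage points higher from compound 1 to compound 3 (within the scatter), a number 9 percentage points higher from compound 2 to compound 3 (within the scatter).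

Compound 4 `CCC(C)OC(=O)C1=C(C)NC(=O)NC1c1ccsc1` is not yet measured. It differs from compound 3 by sec-butoxy in place of diethylamino on a carbonyl carbon. The three measured steps are the ones that bear on this change, since each also exchanges the group on that carbonyl carbon, and each stayed within the scatter. Among the measured compounds shown here, with no measured step at this position moving the number beyond the scatter, the expectation for sec-butoxy is a step of the same kind, with no direction claimed; the estimated step is a number 3 percentage points lower from compound 3 to compound 4 (within the scatter). Compound 4 is therefore expected to give about 8% in this assay, with the estimate ranging from 0% to 20%.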

Compound 4, a percentage reported as inhibition, at one concentration (the size of the read-out at that concentration, not a potency): 5%
Compound 4: middle estimate off by 3 percentage points, on the high side; the measured number falls inside the stated range.
By their numbers in this assay, from the lowest: compounds 2, 4, 1 and 3 (each within the scatter of the next).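

Among these compounds, the sec-butoxy group puts an oxygen-linked group on the carbonyl carbon for the first time in this set, and in this assay it too stays inside the scatter against all three earlier groups (diethylamino: a number 6 percentage points lower from compound 3 to compound 4 (within the scatter); amino: a number 3 percentage points higher from compound 2 to compound 4 (within the scatter); methyl: a number 4 percentage points lower from compound 1 to compound 4 (within the scatter)). The exchange with diethylamino keeps the heavy-atom count the same and swaps nitrogen for oxygen, adding the hydrogen-bond acceptor counted for sec-butoxy, yet this produces no step beyond the scatter, so all four groups at this position remain indistinguishable in this read-out. No measurement in hand offers an explanation for these values.

On these data alone, it remains open whether a carboxylic acid, a benzyloxy group or a longer alkoxy chain on this carbonyl carbon would give a step beyond the scatter in this assay. As far as these compounds go, it is also open whether a change elsewhere on the shared core, with any of these four groups kept in place, would move the number more than the exchanges at this position have.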